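This account rests on a few compounds, and the source may have more. Where it says the series, first, only, none or still open, it means among the compounds named here.

Three compounds share one core and differ only in a single group. Compound 1 `COc1ncnc2c1c(I)cn2[C@@H]1O[C@H](CO)[C@@H](O)[C@H]1O`, compound 2 `COc1ncnc2c1c(-c1ccsc1)cn2[C@@H]1O[C@H](CO)[C@@H](O)[C@H]1O` and compound 3 `COc1ncnc2c1c(-c1cc3ccccc3o1)cn2[C@@H]1O[C@H](CO)[C@@H](O)[C@H]1O` were all tested in a functional assay on HCT-116 cells (Homo sapiens), read by MTT assay, with a stated time of 72 h; a higher number here means a weaker inhibitor, a lower number a stronger inhibitor. For compound 1 the result in this assay is a limit rather than a number, > 20000 nM, as marked by the limit of > 20000 nM in this assay, at which 1 of the 3 values shown sits. Compound 2 gives 120 nM in this assay, and compound 3 gives 13800 nM. Of the two actual numbers, compound 2 holds the lowest, and the gap to its nearest neighbour is large: a 120-fold higher number from compound 2 to compound 3 (2.06 log units; beyond the scatter). Exchanging the iodo group produces very different outcomes, an at least 160-fold lower number from compound 1 to compound 2 (2.22 log units; beyond the scatter) on one side and an at least 1.4-fold lower number from compound 1 to compound 3 (0.16 log units; that floor lies within the scatter) on the other.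

Compound 4 `Cc1ncnc2c1c(-c1ccsc1)cn2[C@@H]1O[C@H](CO)[C@@H](O)[C@H]1O` has not yet been measured. It differs from compound 2 by methyl in place of methoxy on an aromatic carbon. Among the measured compounds shown here, every measured step above exchanges the iodo, thiophen-3-yl or 1-benzofuran-2-yl group; none alters the methoxy, so no measured step bears directly on this change. With the thiophen-3-yl group of compound 2 kept, and nothing in the data pointing either way, the expectation is a step that stays within the usual scatter, with a wide range to reflect the lack of evidence. Compound 4 is thus expected to give about 200 nM in this assay, somewhere between 50 nM and 1500 nM. The expected step is a 1.7-fold higher number from compound 2 to compound 4 (0.22 log units; within the scatter).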

Compound 4, half-maximal inhibitory concentration: 460 nM
Compound 4: middle estimate off by 2.3-fold (0.36 log units), on the low side; measured number inside the range.
By their numbers in this assay, from the lowest: compound 2; then compound 4; then compound 3. At a limit, above all of these: compound 1.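

Until now every step changed a different group, so the methoxy might have made no difference to the result. In this assay, the replacement by methyl on this aromatic carbon, next to the ring nitrogen, gives a 3.8-fold higher number from compound 2 to compound 4 (0.58 log units; beyond the scatter), which shows that the group here does affect the number, with the methoxy version the stronger inhibitor of this pair. The step is still modest beside the exchange of the other group, a 120-fold higher number from compound 2 to compound 3 (2.06 log units; beyond the scatter), and nothing in the data shown explains why losing the oxygen of the methoxy moves the number in this direction.

Going by these compounds, this single pair cannot show how the position responds in general: whether an amine, a hydroxyl group or a longer chain such as ethoxy here would give a lower or a higher number remains open. It is also open whether the methyl-for-methoxy exchange would have a similar effect alongside the iodo or 1-benzofuran-2-yl group, since the only pair shown carries thiophen-3-yl.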